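A few compounds are considered here, and "the series" means these few. Any claim that something is new, unique, unknown or untested is made for them only; others in the source may bear on it.

Compound 1, with the structure `CC(C)n1nc(-c2ccnc3[nH]c(C4CCN(CC(=O)N(C)C)CC4)cc23)ccc1=O`, was tested in an ADME assay (Rattus norvegicus, strain Han-wistar) for pharmacokinetics, at a dose of 1.5 umol/kg by the intravenous route (a higher number here means faster removal of the compound, a lower number slower removal), where compound 1 gives 72 mL/min/kg. Going by the values given here, that is the lowest of the two numbers measured so far. Among the compounds with values here, the only other measured compound, compound 2, with the structure `CC(C)n1cc(-c2ccnc3[nH]c(C4CCN(CC(=O)N5CCCCC5)CC4)cc23)ccc1=O`, gives in this assay a value of 159 mL/min/kg, a number beyond the usual scatter above that of compound 1; the two compounds differ in more than one place, so the two values alone say nothing about any single change.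

Compound 3, with the structure `CC(C)n1cc(-c2ccnc3[nH]c(C4CCN(CC(=O)N(C)C)CC4)cc23)cnc1=O`, has not yet been measured. It differs from compound 1 in one place: a group of 10 heavy atoms (7 carbon, 2 nitrogen, 1 oxygen; one six-membered aromatic ring with 2 hetero atoms) in place of a group of 10 heavy atoms (7 carbon, 2 nitrogen, 1 oxygen; one six-membered aromatic ring with 2 hetero atoms), on an aromatic carbon. The group that enters and the group that leaves hold the same atoms, joined differently, on the same aromatic carbon.

Within the data shown here, with no single-change step measured between compounds here, the step from compound 1 to compound 3 is expected to be small, a 1.2-fold higher number from compound 1 to compound 3 (0.07 log units; within the scatter), and may lie within the scatter. Compound 3 is therefore expected to give about 85 mL/min/kg in this assay, within a range from 40 mL/min/kg to 180 mL/min/kg.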

Compound 3, clearance: 72 mL/min/kg
Estimate against measurement, compound 3: 1.2-fold (0.07 log units) above; the measured number falls inside the stated range.
By their numbers in this assay, from the lowest: compounds 1 and 3 (each within the scatter of the next); then compound 2.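

In this assay, going by these compounds alone, this is the first single change that can be read: one six-membered aromatic ring with 2 hetero atoms is replaced by another built from the same atoms, joined differently, on the same aromatic carbon, and the result is no change at the digits printed from compound 1 to compound 3 (within the scatter). For this pair, with the rest of the structure held fixed, rearranging these ring atoms leaves clearance unresolved from the scatter. Nothing available here explains this result.

From the compounds shown here alone, it remains open whether a plain phenyl ring, or a pyridine ring with a single nitrogen, at this position would give a step beyond the scatter. Compound 2 differs from compound 1 and compound 3 in more than one place, so the effect of its piperidine amide, compared with the dimethyl amide, cannot be read on its own.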